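The source may hold more compounds than are shown below. What is called first, only, known or untested is meant among the compounds shown, and "the series" means these compounds.

In a functional assay on U-937 cells (Homo sapiens), read by cAMP accumulation (a lower number here means that less compound is needed, a higher number that more compound is needed for the effect), compound 2 (`CCc1nn(C2CCCC2)c2c1CCN(c1ccccc1)C2=O`) gives 70 nM and stands lowest of three numbers, while compound 1 (`CCc1nn(-c2ccc(F)cc2)c2c1CCN(c1ccccc1)C2=O`) gives 880 nM and compound 3 (`CCc1nn(-c2ccc(F)cc2)c2c1CCN(c1cccc(C)c1)C2=O`) gives 780 nM in the same test. Compound 4 (`CCc1nn(C2CCCC2)c2c1CCN(c1cccs1)C2=O`) differs from compound 2 by thiophen-2-yl in place of phenyl on an amide-type nitrogen in a ring. Cyclopentyl in place of 4-fluorophenyl gave a 13-fold lower number from compound 1 to compound 2 (1.10 log units; beyond the scatter) but sits on an aromatic nitrogen. Methyl in place of hydrogen on an aromatic carbon, the only measured change in the group on the amide-type nitrogen, gave a 1.1-fold lower number from compound 1 to compound 3 (0.05 log units; within the scatter) and is the closer guide. Among the compounds with values here, no measured compound carries thiophen-2-yl, so the guide is indirect, and no step beyond the scatter is expected in this assay here. Compound 4 is estimated at 80 nM with an expected range from 30 nM to 210 nM in this test. The estimated change is a 1.1-fold higher number from compound 2 to compound 4 (0.06 log units; within the scatter) and no more than that.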

Compound 4, half-maximal effective concentration: 1 nM
Estimate against measurement, compound 4: 80-fold (1.90 log units) above; measured number outside the range, below it.
By their numbers in this assay, from the lowest: compound 4; then compound 2; then compounds 3 and 1 (each within the scatter of the next).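

In this assay, the amide-type nitrogen in a ring turns out to be a position where one aryl group can replace another with a large effect: thiophen-2-yl in place of phenyl gave a 70-fold lower number from compound 2 to compound 4 (1.85 log units; beyond the scatter). The only earlier change in this group, a methyl on the phenyl ring, gave a 1.1-fold lower number from compound 1 to compound 3 (0.05 log units; within the scatter), so that step had not shown how much this position can matter.

Going by these compounds, whether furan-2-yl or pyridin-2-yl on this nitrogen would act like thiophen-2-yl remains open, as does whether the step would hold with 4-fluorophenyl instead of cyclopentyl on the aromatic nitrogen. Nothing at hand accounts for the size of the step.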